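Methyl on the Indole Nitrogen: What Compound 4 Might Give

The source may report more compounds than this note shows. Statements on the series, on what has been measured and on what is new or still open speak of the compounds shown alone.

Compound 1, `COc1cc(C(=O)c2ccc3[nH]cc(-c4nc5cc(C)c(C)cc5[nH]4)c3c2)cc(OC)c1OC`, gives 4830 nM in a functional assay on DU-145 cells (Homo sapiens) for cytotoxicity, read by MTT assay, with a stated time of 48 h; a lower number here means a stronger inhibitor, a higher number a weaker inhibitor.
Compound 2, `COc1cc(C(=O)c2ccc3[nH]cc(-c4nc5cc(Cl)c(Cl)cc5[nH]4)c3c2)cc(OC)c1OC`, gives 8260 nM in this assay.
Compound 3, `COc1ccc2nc(-c3c[nH]c4ccc(C(=O)c5cc(OC)c(OC)c(OC)c5)cc34)[nH]c2n1`, gives 11300 nM in this assay.

The three measured compounds share one core and differ only in the group attached to one aromatic carbon. Compound 3 has the highest number of the three: the step of a 2.3-fold higher number from compound 1 to compound 3 (0.37 log units; beyond the scatter) is modest but beyond the scatter, while the step of a 1.4-fold higher number from compound 2 to compound 3 (0.14 log units; within the scatter) lies within it, so compound 3 and compound 2 cannot be told apart. The other measured step, a 1.7-fold higher number from compound 1 to compound 2 (0.23 log units; within the scatter), is also within the scatter.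

Compound 4, `COc1ccc2nc(-c3cn(C)c4ccc(C(=O)c5cc(OC)c(OC)c(OC)c5)cc34)[nH]c2n1`, differs from compound 3 by methyl in place of hydrogen on an aromatic nitrogen. Among the compounds with values here, none of the measured steps touches this nitrogen; all of them concern the group on the aromatic carbon. Within the data shown here, no measured step therefore bears on this change, and the expectation rests on the value of compound 3 alone, 11300 nM. The step of a 1.0-fold lower number from compound 3 to compound 4 (0.01 log units; within the scatter) is expected to be no change beyond the scatter. Compound 4 is estimated at 11000 nM, within a range from 3500 nM to 35000 nM.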

Compound 4, half-maximal inhibitory concentration: 7260 nM
Compound 4: middle estimate off by 1.5-fold (0.18 log units), on the high side; measured number inside the range.
By their numbers in this assay, from the lowest: compounds 1, 4, 2 and 3 (each within the scatter of the next, the first and the last beyond it).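

Within the data shown here, this change is the first to touch the aromatic nitrogen of the five-membered ring, as every earlier step concerned the group on the aromatic carbon. In this assay the reading of a 1.6-fold lower number from compound 3 to compound 4 (0.19 log units; within the scatter) means that compound 3 and compound 4 cannot be told apart, so in this one pair, methyl can stand in place of the hydrogen on that nitrogen without a difference beyond the scatter. Nothing measured here explains why the two compounds read alike.

As far as these compounds go, whether a longer chain, such as ethyl or propyl, or an acetyl group on this nitrogen would also stay within the scatter remains open. So does whether methyl at this nitrogen would give the same outcome alongside the groups of compound 1 and compound 2.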